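The compounds below may be only part of what the source reports. "The series", "measured", "known", "first", "only" and "open" are said of these compounds alone.

Measured so far in a functional assay on the whole organism (artery, strain albino) with Rattus norvegicus as the target, with a stated time of 60 min, at a dose of 10 mg/kg by the oral route; on this read-out lower numbers stand for less inhibition and higher numbers for more inhibition at the one dose given (going by the name of the read-out):
- compound 1, `COc1ccc(C2N=C(SCc3ccccc3)NC(C)=C2C(=O)Nc2ccc(Br)cc2)cc1` — 5.6%
- compound 2, `COc1ccc(C2N=C(SCc3ccccc3Cl)NC(C)=C2C(=O)Nc2ccc(Br)cc2)cc1` — 6.7%
- compound 3, `COc1ccc(C2N=C(SCc3cccc(Cl)c3)NC(C)=C2C(=O)Nc2ccc(Br)cc2)cc1` — 15.4%

Compound 3 gives the highest of the three numbers, but the step of a number 8.7 percentage points higher from compound 2 to compound 3 (within the scatter) and the step of a number 9.8 percentage points higher from compound 1 to compound 3 (within the scatter) are both within the scatter, so no ordering among the three is supported. The step of a number 1.1 percentage points higher from compound 1 to compound 2 (within the scatter) is likewise within the scatter. Taken together, the three values say that moving chloro around the benzyl ring has so far produced nothing beyond the usual spread of this read-out.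

Compound 4, `COc1ccc(C2N=C(SCc3ccc(Cl)cc3)NC(C)=C2C(=O)Nc2ccc(Br)cc2)cc1`, differs from compound 3 as follows: 4-chlorophenyl in place of 3-chlorophenyl on a saturated chain carbon bound to a sulfur.

Going by the values given here, the steps that bear on this change are those that also move or add chloro on the same ring: the step from compound 1 to compound 2, from compound 1 to compound 3, and from compound 2 to compound 3. None of them exceeded the scatter. The expectation for this assay is therefore a step of no real size in either direction, with compound 4 landing somewhere in the band spanned by the three measured compounds.

The estimated step is a number 5.4 percentage points lower from compound 3 to compound 4 (within the scatter), which is expected to lie within the scatter. Compound 4 is thus expected to give about 10%, in a range from 0% to 22%.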

Compound 4, a percentage reported as inhibition, in the whole organism at one dose (the size of the read-out at that dose, not a potency): 12.3%
The estimate for compound 4 lay 2.3 percentage points below the measured number, and the stated range covers the measured number.
By their numbers in this assay, from the lowest: compounds 1, 2, 4 and 3 (each within the scatter of the next).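

In this assay, 4-chlorobenzyl in place of 3-chlorobenzyl on the sulfur gives a number 3.1 percentage points lower from compound 3 to compound 4 (within the scatter), 4-chlorophenyl in place of 2-chlorophenyl at the same saturated chain carbon gives a number 5.6 percentage points higher from compound 2 to compound 4 (within the scatter), and chloro in place of hydrogen to give the 4-chlorobenzyl group gives a number 6.7 percentage points higher from compound 1 to compound 4 (within the scatter). With compound 4 added, the unsubstituted benzyl group and the 2-chlorophenyl, 3-chlorophenyl and 4-chlorophenyl groups all lie within the scatter of one another, so none of these chloro placements stands apart from the others or from hydrogen in this read-out at the one dose given. Nothing available explains where these numbers fall.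

From the compounds shown here alone, whether a group other than chloro on the benzyl ring, such as an amine or a carboxylic acid, would give a step beyond the scatter remains open. Also open, going by these compounds, is whether a longer chain in place of the single saturated carbon bound to the sulfur, or any change to the rest of the shared core, would do so.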